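A few compounds are considered here, and "the series" means these few. Any claim that something is new, unique, unknown or untested is made for them only; others in the source may bear on it.

Working notes on the series. Compound 1 `COc1ccccc1C(=O)Nc1cccc(-c2oc3cc(-c4ccc(F)cc4)ccc3c(=O)c2O)c1` and compound 2 `O=C(Nc1cccc(-c2oc3cc(-c4ccc(F)cc4)ccc3c(=O)c2O)c1)c1ccc(Br)cc1` share one core and differ only in the aryl on the carbonyl carbon. In a functional assay on HepG2 cells (Homo sapiens) for antiproliferative activity, read by CCK-8 assay, with a stated time of 72 h (on this read-out lower numbers stand for stronger inhibition and higher numbers for weaker inhibition), compound 1 gives 14500 nM and compound 2 gives 13900 nM, a step of a 1.0-fold lower number from compound 1 to compound 2 (0.02 log units; within the scatter). Compound 3 `O=C(Nc1cccc(-c2oc3cc(-c4ccc(F)cc4)ccc3c(=O)c2O)c1)c1ccc(Br)cc1F` returns only a limit in this assay, > 100000 nM, the value at the limit of > 100000 nM in this assay, at which 1 of the 3 values shown sits. Compound 3 is thus the weakest of the three, with an at least 6.8-fold higher number from compound 1 to compound 3 (0.83 log units; beyond the scatter) and an at least 7.1-fold higher number from compound 2 to compound 3 (0.85 log units; beyond the scatter). Compound 4 `O=C(Nc1cccc(-c2oc3cc(-c4ccc(F)cc4)ccc3c(=O)c2O)c1)c1cc(F)cc(F)c1` takes the next step: 3,5-difluorophenyl in place of 4-bromo-2-fluorophenyl on a carbonyl carbon. The one-fluorine step from compound 2 to compound 3 was the large one; the aryl swap from compound 1 to compound 2 was within scatter. Compound 4 drops the bromine and that fluorine, so a numbered value is expected again, an at least 3.3-fold lower number from compound 3 to compound 4 (0.52 log units; beyond the scatter). Compound 4 is estimated at 30000 nM, within 9000 nM to 100000 nM.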

Compound 4, half-maximal inhibitory concentration: 4960 nM
The estimate for compound 4 lay 6.0-fold (0.78 log units) above the measured number; the whole stated range lies above it.
By their numbers in this assay, from the lowest: compound 4; then compounds 2 and 1 (each within the scatter of the next). At a limit, above all of these: compound 3.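

In this assay, going by these compounds alone, 3,5-difluorophenyl on the carbonyl carbon is the first aryl to give a stronger number than the others, with a 2.8-fold lower number from compound 2 to compound 4 (0.45 log units; beyond the scatter) and a 2.9-fold lower number from compound 1 to compound 4 (0.47 log units; beyond the scatter), so this position can also move the number downward. Two fluorines on the aryl are compatible with activity, as an at least 20-fold lower number from compound 3 to compound 4 (1.30 log units; beyond the scatter) shows, so fluorine alone does not bring the loss seen with compound 3. Compound 3 stands at a limit, which leaves the size of that step open-ended: the limit of > 100000 nM in this assay, at which 1 of the 4 values shown sits.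

Open, from the compounds shown here alone, is how an aryl carrying an amine or a carboxylic acid would read at this position. Also open, going by these compounds, is whether a cyclohexyl in place of the aryl would keep the number of compound 4.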